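This account rests on a few compounds, and the source may have more. Where it says the series, first, only, none or still open, it means among the compounds named here.

Measured so far:
Compound 1 `c1ccc(C2CC3(N4CCCCC4)CCN(CCCN4CCCCC4)C2C(c2ccccc2)C3)cc1`: 138000 nM
Compound 2 `O=C(CCN1CCCCC1)N1CCC2(N3CCCC3)CC(c3ccccc3)C1C(c1ccccc1)C2`: 108000 nM

In an ADME assay on L6 cells (Rattus norvegicus) for cytotoxicity (on this read-out higher numbers stand for weaker inhibition and lower numbers for stronger inhibition), compound 2 gives 108000 nM, and compound 1 gives 138000 nM; the two numbers lie within the usual scatter of each other, so the series shows no separation yet on this read-out.

Compound 3 `c1ccc(C2CC3(N4CCCC4)CCN(CCCN4CCCCC4)C2C(c2ccccc2)C3)cc1` is not yet measured. It differs from compound 2 in one place: 3-(piperidin-1-yl)propyl in place of (2-(piperidin-1-yl)ethyl)carbonyl on an amine nitrogen in a ring. For the measured compounds named here, no step between measured compounds covers this change, so its size is not known from the data. Because compound 1, which carries the same 3-(piperidin-1-yl)propyl group, gives 138000 nM, and compound 2 gives 108000 nM, no step beyond the scatter is expected here. The expected step is a 1.1-fold higher number from compound 2 to compound 3 (0.05 log units; within the scatter). For compound 3 the estimate in this assay is 120000 nM, with a range from 60000 nM to 240000 nM.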

Compound 3, half-maximal inhibitory concentration: 28700 nM
The estimate for compound 3 lay 4.2-fold (0.62 log units) above the measured number; the whole stated range lies above it.
By their numbers in this assay, from the lowest: compound 3; then compounds 2 and 1 (each within the scatter of the next).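

In this assay the series now separates: with pyrrolidin-1-yl on the saturated ring carbon, 3-(piperidin-1-yl)propyl in place of (2-(piperidin-1-yl)ethyl)carbonyl on the amine nitrogen in a ring gives a 3.8-fold lower number from compound 2 to compound 3 (0.58 log units; beyond the scatter) beyond the scatter, so the two chains are not interchangeable on this read-out. With the 3-(piperidin-1-yl)propyl chain held fixed, pyrrolidin-1-yl in place of piperidin-1-yl gives a 4.8-fold lower number from compound 1 to compound 3 (0.68 log units; beyond the scatter) on the same read-out, so the saturated ring carbon responds as well. No available measurement accounts for either step.

From the compounds shown here alone, whether the chain step holds with piperidin-1-yl on the saturated ring carbon remains open. Also open, going by these compounds, is how the number moves with an open-chain dimethylamino group at that carbon, or with a longer chain on the ring nitrogen.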